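The source may hold more compounds than are shown below. What is called first, only, known or untested is meant among the compounds shown, and "the series" means these compounds.

Compound 1, `C/C=C/C(=O)Nc1cccc(Oc2nc(Nc3ccn(C)n3)nc3c2CSCC3)c1`, reaches only the limit > 50000 nM in a functional assay on HeLa cells (Homo sapiens) for antiproliferative activity, read by MTT assay, with a stated time of 72 h; a higher number here means a weaker inhibitor, a lower number a stronger inhibitor.
Compound 2, `CC/C=C/C(=O)Nc1cccc(Oc2nc(Nc3ccn(C)n3)nc3c2CSCC3)c1`, likewise reaches only the limit > 50000 nM in this assay.
Compound 3, `C/C=C/C(=O)Nc1cccc(Oc2nc(Nc3ccc(OC)nc3)nc3c2CSCC3)c1`, gives 16500 nM in this assay.

Compounds 1 and 2 share a core and differ by methyl in place of hydrogen on a saturated chain carbon bound to a double-bonded chain carbon. Both values are limits, so the step that the two limits leave unreadable from compound 1 to compound 2 cannot be sized; the limit in question is the limit of > 50000 nM in this assay, at which 2 of the 3 values shown sit. Compound 3 differs from compound 1 by 6-methoxypyridin-3-yl in place of 1-methyl-1H-pyrazol-3-yl on a nitrogen on an aromatic ring, and this change produced an at least 3.0-fold lower number from compound 1 to compound 3 (0.48 log units; beyond the scatter). Compound 4, `CC/C=C/C(=O)Nc1cccc(Oc2nc(Nc3ccc(OC)nc3)nc3c2CSCC3)c1`, is not yet measured; it differs from compound 3 by methyl in place of hydrogen on a saturated chain carbon bound to a double-bonded chain carbon, the same change as that from compound 1 to compound 2. Resting on compound 3 with 16500 nM, compound 4 is expected to give 20000 nM, somewhere from 8000 nM to 50000 nM. This corresponds to an expected step of a 1.2-fold higher number from compound 3 to compound 4 (0.08 log units; within the scatter), set beside a step that the two limits leave unreadable from compound 1 to compound 2, which gave no readable size.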

Compound 4, half-maximal inhibitory concentration: 31200 nM
For compound 4 the middle estimate is 1.6-fold (0.19 log units) below the measured one; the range from low to high includes it.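

In this assay, putting 6-methoxypyridin-3-yl in place of 1-methyl-1H-pyrazol-3-yl on the second core gives an at least 1.6-fold lower number from compound 2 to compound 4 (0.20 log units; that floor lies within the scatter), and this can be set beside the first core: the same change on two cores in this assay, an at least 3.0-fold lower number (0.48 log units; beyond the scatter) from compound 1 to compound 3 and an at least 1.6-fold lower number (0.20 log units; that floor lies within the scatter) from compound 2 to compound 4; the limit leaves it open whether they differ. The methyl that turns prop-1-en-1-yl into but-1-en-1-yl gives a 1.9-fold higher number from compound 3 to compound 4 (0.28 log units; within the scatter), while its step on the other core cannot be read, as with every step between two limits: the limit of > 50000 nM in this assay, at which 2 of the 4 values shown sit. So the series shows that compound 4 leaves the limit, but it does not show that either change carries over with the same size.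

Open, on these data alone, is whether a longer chain than but-1-en-1-yl, or an amine on that chain, would change the number in a readable way.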